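Removing a Bromine from a Menthyl Benzoate

A few compounds are considered here, and "the series" means these few. Any claim that something is new, unique, unknown or untested is made for them only; others in the source may bear on it.

Three esters built on one shared core have been measured in a physicochemical assay for lipophilicity, measured as octanol-water partition; a lower number here means a more polar compound, a higher number a more lipophilic compound. Compound 1 `Cc1cccc(C(=O)O[C@@H]2C[C@H](C)CC[C@H]2C(C)C)c1` gives 5.29. Compound 2 `CC(C)[C@@H]1CC[C@@H](C)C[C@H]1OC(=O)c1ccc(Cl)cc1` gives 5.34. Compound 3 `CC(C)[C@@H]1CC[C@@H](C)C[C@H]1OC(=O)c1ccccc1Br` gives 5.61, the highest of the three numbers; compound 2 lies within the usual scatter of it, while compound 1 sits beyond the scatter below it. The next compound, compound 4 `CC(C)[C@@H]1CC[C@@H](C)C[C@H]1OC(=O)c1ccccc1`, is not yet measured. It differs from compound 3 in one place: hydrogen in place of bromo on an aromatic carbon. In this assay, a step from compound 3 to compound 4 of a number 0.76 log units lower from compound 3 to compound 4 (beyond the scatter) is expected, a fall clearly beyond the scatter. Compound 4 is therefore estimated at 4.85, with a likely range from 4.5 to 5.2.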

Compound 4, partition coefficient: 4.82
The estimate for compound 4 lay 0.03 log units above the measured number, within the range that was stated.
By their numbers in this assay, from the lowest: compound 4; then compounds 1, 2 and 3 (each within the scatter of the next, the first and the last beyond it).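

In this assay, hydrogen in place of bromo gives a number 0.79 log units lower from compound 3 to compound 4 (beyond the scatter) and hydrogen in place of chloro gives a number 0.52 log units lower from compound 2 to compound 4 (beyond the scatter) while hydrogen in place of methyl gives a number 0.47 log units lower from compound 1 to compound 4 (beyond the scatter). Compound 4, with hydrogen, therefore has the lowest number of the four, and each of the three groups carries a higher number than hydrogen. Nothing shown here explains the size of these steps.

Going by these compounds, whether an amine or a carboxylic acid on the aromatic ring would take the number below that of compound 4 remains open.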